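The compounds below may be only part of what the source reports. "The series", "measured", "known", "first", "only" and "open" are said of these compounds alone.

The numbers come from an ADME assay on HEK293 cells (Homo sapiens) for cytotoxicity, read by resazurin assay, with a stated time of 48 h; a higher number here means that more compound is tolerated, a lower number that less compound is tolerated. Compound 1, `O=S(=O)(Nc1ccc(-c2nc3ccccc3o2)cc1)c1cccc(Cl)c1`, reaches only the limit of the assay, reported as > 100000 nM. Compound 2, `O=S(=O)(Nc1ccc2oc(-c3ccccc3)nc2c1)c1ccccc1Cl`, gives 73000 nM. Compound 3, `O=S(=O)(Nc1ccc2oc(-c3ccccc3)nc2c1)c1cccs1`, gives 97000 nM. Exchanging the 2-chlorophenyl on the sulfonyl sulfur for thiophen-2-yl yields a 1.3-fold higher number from compound 2 to compound 3 (0.12 log units; within the scatter), a gap that does not count as a real difference. Among the numbers shown, compound 3 therefore stands next to compound 2, separated from it only by scatter, while the one remaining compound reports a limit rather than a number.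

Compound 4, `O=S(=O)(Nc1ccc2oc(-c3ccccc3)nc2c1)c1cccc(O)c1`, has not been measured. It differs from compound 3 in a single place: 3-hydroxyphenyl in place of thiophen-2-yl on a sulfonyl sulfur. Going by the values given here, the only measured step that touches the same position is the swap of the group on the sulfonyl sulfur between compound 2 and compound 3, and that step stayed within the scatter. The limit of > 100000 nM in this assay, at which 1 of the 3 values shown sits, shows that a further member of this group was tolerated up to the top of the range tested. On this basis a step of about a 1.1-fold lower number from compound 3 to compound 4 (0.03 log units; within the scatter) is expected for compound 4 in this assay, that is, nothing beyond the scatter. The estimate for compound 4 is 90000 nM, with a range from 45000 nM to 180000 nM.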

Compound 4, half-maximal cytotoxic concentration: > 100000 nM
Compound 4 ended at the assay's limit; the forecaster's own chance of this, stated with the estimate: 35%; at least 1.1-fold (0.04 log units) between middle value and limit.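

In this assay, the group on the sulfonyl sulfur now changes from a five-membered ring with a sulfur atom to a six-membered carbon ring carrying a hydroxyl, which adds a hydrogen-bond donor, and this gives an at least 1.0-fold higher number from compound 3 to compound 4 (0.01 log units; that floor lies within the scatter). Set against the 2-chlorophenyl group, the same 3-hydroxyphenyl group gives an at least 1.3-fold higher number from compound 2 to compound 4 (0.13 log units; that floor lies within the scatter), so with both floors inside the scatter, neither step proves a real rise, but neither shows any sign that the new group makes the compound less well tolerated. The result for compound 4 is a limit and not a number, so this position accepts the hydroxyl without a measurable penalty, and the series now reaches the top of the tested range more than once: the limit of > 100000 nM in this assay, at which 2 of the 4 values shown sit.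

From the compounds shown here alone, how far the true value of compound 4 lies past its limit cannot be read, so the size of both steps remains unknown. Going by these compounds, it also remains open whether an amine or a carboxylic acid on this ring, or a longer chain in its place on the sulfonyl sulfur, would leave the number unchanged or bring it down.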